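Changing the Aryl Group on the Carbonyl: Compound 3 to Compound 4

The source may hold more compounds than are shown below. What is called first, only, known or untested is meant among the compounds shown, and "the series" means these compounds.

Of the compounds shown here, three sharing one core have been measured in an in vitro ADME assay on microsomes from liver (Homo sapiens) for metabolic stability; on this read-out lower numbers stand for slow clearance and higher numbers for fast clearance. There, compound 1 `CC(C)NC(=O)[C@H]1CC[C@@H](n2/c(=N/C(=O)c3cc(F)cc(Cl)c3)[nH]c3ccc(CN4CCC(C(C)(C)O)CC4)cc32)CC1` gives 83 mL.min-1.g-1, compound 2 `CC(C)NC(=O)[C@H]1CC[C@@H](n2/c(=N/C(=O)c3cccc(C#N)c3)[nH]c3ccc(CN4CCC(C(C)(C)O)CC4)cc32)CC1` gives 72 mL.min-1.g-1 and compound 3 `CC(C)NC(=O)[C@H]1CC[C@@H](n2/c(=N/C(=O)c3ccncc3)[nH]c3ccc(CN4CCC(C(C)(C)O)CC4)cc32)CC1` gives 57 mL.min-1.g-1. Compound 3 thus stands within the scatter of both other compounds. Compound 4 `CC(C)NC(=O)[C@H]1CC[C@@H](n2/c(=N/C(=O)c3cc(F)cc(C#N)c3)[nH]c3ccc(CN4CCC(C(C)(C)O)CC4)cc32)CC1`, still unmeasured, keeps the same core but carries 3-cyano-5-fluorophenyl in place of pyridin-4-yl on a carbonyl carbon.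

All three measured steps were made at this same place. Pyridin-4-yl in place of 3-cyanophenyl gave a 1.3-fold lower number from compound 2 to compound 3 (0.10 log units; within the scatter), and pyridin-4-yl in place of 3-chloro-5-fluorophenyl gave a 1.5-fold lower number from compound 1 to compound 3 (0.16 log units; within the scatter). The third exchange, 3-cyanophenyl in place of 3-chloro-5-fluorophenyl, gave a 1.2-fold lower number from compound 1 to compound 2 (0.06 log units; within the scatter). Compound 4 shares its nitrile with compound 2 and its fluorine with compound 1, so its value is expected to fall close to theirs. None of these steps leaves the scatter, so no step beyond the scatter is expected in this assay. The step expected is a 1.3-fold higher number from compound 3 to compound 4 (0.11 log units; within the scatter). The estimate for compound 4 is 74 mL.min-1.g-1, with an expected range from 45 mL.min-1.g-1 to 120 mL.min-1.g-1.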

Compound 4, intrinsic clearance in microsomes: 90 mL.min-1.g-1
Estimate against measurement, compound 4: 1.2-fold (0.09 log units) below; the measured number falls inside the stated range.
By their numbers in this assay, from the lowest: compounds 3, 2, 1 and 4 (each within the scatter of the next).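

In this assay, replacing the ring with a nitrogen by a carbon-only ring carrying a nitrile and a fluorine gives a 1.6-fold higher number from compound 3 to compound 4 (0.20 log units; within the scatter), so even this exchange of the whole aryl group on the carbonyl stays within the scatter. Within the data shown here, the new compound also allows the first readings of single substituents on the ring, and both stay within the scatter: fluoro in place of hydrogen gives a 1.3-fold higher number from compound 2 to compound 4 (0.10 log units; within the scatter), and cyano in place of chloro gives a 1.1-fold higher number from compound 1 to compound 4 (0.04 log units; within the scatter). Across these four aryl groups, then, the assay separates none of the listed steps from the scatter, and nothing at hand offers an explanation for this.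

On these data alone, all four compounds carry a six-membered aromatic ring on the carbonyl, so it remains open whether a saturated alkyl chain or a cyclohexyl group there would leave the clearance within the same scatter. As far as these compounds go, it also remains open how a carboxylic acid or an aliphatic amine on the aryl ring would read in this assay, and whether the other parts of the shared core would respond more strongly than this position has.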